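Glycine transporter series: aryl change from compound 3 to compound 4

The source may report more compounds than this note shows. Statements on the series, on what has been measured and on what is new or still open speak of the compounds shown alone.

Values in an assay on cells for inhibition of sodium- and chloride-dependent glycine transporter 1 (Homo sapiens); on this read-out higher numbers stand for an effect only at larger amounts of compound and lower numbers for an effect already at smaller amounts:
compound 1 `COc1cc(C(F)(F)F)cc(C(F)(F)F)c1C(=O)NC1(c2ccccc2)CCCN(CC2CC2)C1`: 380 nM
compound 2 `COc1cccc(C(F)(F)F)c1C(=O)NC1(c2ccccc2)CCCN(C)C1`: 1500 nM
compound 3 `COc1cc(C(F)(F)F)cc(SC)c1C(=O)NC1(c2ccc(Cl)cc2)CCCN(C)C1`: 28 nM

Compound 3 has the lowest number of the three in this assay; compound 1 is the nearest to it and compound 2 the furthest, both gaps beyond the scatter. Compound 4 `COc1cc(C(F)(F)F)cc(SC)c1C(=O)NC1(c2cccc(F)c2)CCCN(C)C1` has not been measured. It differs from compound 3 in one place: 3-fluorophenyl in place of 4-chlorophenyl on a saturated ring carbon. Going by the values given here, no measured pair in this set isolates that change, and compound 2 differs from compound 3 in more than one place, so its value cannot be read against compound 3 for this change alone. A moderate rise in the number, somewhat beyond the scatter, is expected. The estimated value of compound 4 in this assay is 65 nM, within a range of 20 nM to 200 nM. The expected step is a 2.3-fold higher number from compound 3 to compound 4 (0.37 log units; beyond the scatter).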

Compound 4, half-maximal effective concentration: 48 nM
Beside the measured number, compound 4's estimate is 1.4-fold (0.13 log units) above it; low and high end bracket the measured number.
By their numbers in this assay, from the lowest: compounds 3 and 4 (each within the scatter of the next); then compound 1; then compound 2.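

Replacing 4-chlorophenyl with 3-fluorophenyl on the saturated ring carbon gives, in this assay, a 1.7-fold higher number from compound 3 to compound 4 (0.23 log units; within the scatter). Going by these compounds alone, this is the first single-place pair, and it shows that this position accepts either halogenated phenyl group with no difference beyond the scatter. No measured data are available to explain this result.

The step changes the halogen and its place on the phenyl ring together, and 3-chlorophenyl or 4-fluorophenyl would separate the two. Going by these compounds, how a pyridine ring or a phenyl ring bearing a carboxylic acid would read at this carbon remains open.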